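The source may report more compounds than this note shows. Statements on the series, on what has been measured and on what is new or still open speak of the compounds shown alone.

In a functional assay on HeLa cells (Homo sapiens) for cytotoxicity, read by sulforhodamine B assay (a higher number here means a weaker inhibitor, a lower number a stronger inhibitor), compound 3 (`CC(NS(=O)(=O)c1ccc(Cl)cc1)C1=CC(=O)c2c(O)ccc(O)c2C1=O`) gives 810 nM. Compound 1 (`CCOC(=O)c1ccc(S(=O)(=O)NC(C2=CC(=O)c3c(O)ccc(O)c3C2=O)C(C)C)cc1`) gives 850 nM, within the scatter of compound 3, so the two stand level. Compound 2 (`CC(NS(=O)(=O)c1ccc(F)cc1)C1=CC(=O)c2c(O)ccc(O)c2C1=O`) gives 6410 nM, a clearly higher number than either.

Next in view is compound 4 (`CCOC(=O)c1ccc(S(=O)(=O)NC(C)C2=CC(=O)c3c(O)ccc(O)c3C2=O)cc1`), with ethoxycarbonyl in place of chloro on an aromatic carbon.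

Within the data shown here, the one measured step at this place is a 7.9-fold lower number from compound 2 to compound 3 (0.90 log units; beyond the scatter), which is beyond the scatter and shows that the number in this assay can respond to a change of group there. That step involves two halogens, so it gives no direct size for ethoxycarbonyl. Among the measured compounds shown here, compound 1 already carries ethoxycarbonyl and gives 850 nM, but its alkyl branch differs from that of compound 4, and no measured step isolates that difference. On this evidence, no shift beyond the scatter is expected, though the uncertainty is wide.

The expected size of the change is a 1.0-fold lower number from compound 3 to compound 4 (0.01 log units; within the scatter). For compound 4 the estimate is 800 nM, with an expected range from 300 nM to 2200 nM.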

Compound 4, half-maximal inhibitory concentration: 2260 nM
Estimate against measurement, compound 4: 2.8-fold (0.45 log units) below; measured number above the stated range.
By their numbers in this assay, from the lowest: compounds 3 and 1 (each within the scatter of the next); then compound 4; then compound 2.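

At the aromatic carbon para to a large group, this assay separates ethoxycarbonyl from both halogens: replacing chloro gives (a 2.8-fold higher number from compound 3 to compound 4 (0.45 log units; beyond the scatter)), while replacing fluoro gives (a 2.8-fold lower number from compound 2 to compound 4 (0.45 log units; beyond the scatter)). Ethoxycarbonyl therefore sits between chloro and fluoro here, and its number cannot be carried over from compound 1 to a compound with a different alkyl branch. With ethoxycarbonyl held fixed, the saturated chain carbon also matters, as methyl in place of isopropyl gives (a 2.7-fold higher number from compound 1 to compound 4 (0.42 log units; beyond the scatter)), and no measured property accounts for either shift.

Going by these compounds, whether this branch step keeps its size with chloro on the aromatic carbon remains open. Also open, on these data alone, is how a carboxylic acid or an amide at the aromatic carbon, or a longer chain at the saturated carbon, would compare.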